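Solubility step from compound 3 to compound 4 in the series

This account rests on a few compounds, and the source may have more. Where it says the series, first, only, none or still open, it means among the compounds named here.

Compound 3 `CN(c1ncco1)c1cnc(NCc2c(F)ccc3c2CCO3)n2cnnc12` gives 67000 nM in a physicochemical assay for solubility, read by LC-MS, in phosphate buffer, with a stated time of 24 h, at pH 7.4 (a lower number here means a less soluble compound, a higher number a more soluble compound), the second highest of the three numbers: compound 1 `O=C1CCCN1c1cnc(NCc2c(F)ccc3c2CCO3)n2cnnc12` gives 640000 nM and compound 2 `Fc1ccc2c(c1CNc1ncc(Oc3ccccc3)c3nncn13)CCO2` gives 8000 nM, so compound 3 sits between them, about as far from each. Compound 4 `COCCC(=O)Nc1cnc(NCc2c(F)ccc3c2CCO3)n2cnnc12` differs from compound 3 in one place: ((2-methoxyethyl)carbonyl)amino in place of methyl(1,3-oxazol-2-yl)amino on an aromatic carbon. The step of a 9.6-fold lower number from compound 1 to compound 3 (0.98 log units; beyond the scatter) bears most on this change, since compound 1 also carries a carbonyl-bearing nitrogen at that position; the step of an 8.4-fold higher number from compound 2 to compound 3 (0.92 log units; beyond the scatter) shows the same position moving the number by a similar amount. A modest rise is therefore expected, the estimated step being a 3.7-fold higher number from compound 3 to compound 4 (0.57 log units; beyond the scatter). Compound 4 is estimated at 250000 nM, within 60000 nM to 1000000 nM.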

Compound 4, solubility: 980000 nM
Estimate against measurement, compound 4: 3.9-fold (0.59 log units) below, within the range that was stated.
By their numbers in this assay, from the lowest: compound 2; then compound 3; then compounds 1 and 4 (each within the scatter of the next).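

In this assay, ((2-methoxyethyl)carbonyl)amino on this aromatic carbon gives a 15-fold higher number from compound 3 to compound 4 (1.17 log units; beyond the scatter) and a 120-fold higher number from compound 2 to compound 4 (2.09 log units; beyond the scatter), while a 1.5-fold higher number from compound 1 to compound 4 (0.19 log units; within the scatter) does not separate it from 2-oxopyrrolidin-1-yl. The number therefore stays at the top of the series with a carbonyl-bearing nitrogen at this position, whether that group has a ring, as in compound 1, or no ring, as in compound 4. Nothing available gives a reason for these steps. On these data alone, whether an amine, a carboxylic acid or a longer chain at this position would keep the number at that level remains open.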